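The source may hold more compounds than are shown below. What is called first, only, known or untested is meant among the compounds shown, and "the series" means these compounds.

Compound 1 `CCOCCNc1nc(C)c(-c2nc3cnccc3s2)c(N[C@@H]2C[C@H](CO)[C@@H](O)[C@H]2O)n1`: 92.1 ng.h/mL
Compound 2 `Cc1nc(N(C)Cc2ccccc2)nc(N[C@@H]2C[C@H](CO)[C@@H](O)[C@H]2O)c1-c1nc2cnccc2s1`: 98.5 ng.h/mL

In an ADME assay on the whole organism (plasma) for pharmacokinetics, with Rattus norvegicus as the target, with a stated time of 6 h, at a dose of 10 mg/kg by the oral route (on this read-out lower numbers stand for lower exposure and higher numbers for higher exposure at the dose given), compound 2 gives 98.5 ng.h/mL, which lies within the scatter of compound 1. Compound 3 `Cc1nc(N[C@H](C)c2ccccc2)nc(N[C@@H]2C[C@H](CO)[C@@H](O)[C@H]2O)c1-c1nc2cnccc2s1` differs from compound 2 on one aromatic carbon: (1-phenylethyl)amino in place of benzyl(methyl)amino on an aromatic carbon. Within the data shown here, only one measured step bears on this change, on the same aromatic carbon: a 1.1-fold higher number from compound 1 to compound 2 (0.03 log units; within the scatter), which lies within the scatter. On that slim evidence, no change beyond the scatter is expected in this assay, and the expected step is a 1.0-fold lower number from compound 2 to compound 3 (0.02 log units; within the scatter). For compound 3 the estimated value is 95 ng.h/mL, with an expected range from 40 ng.h/mL to 220 ng.h/mL.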

Compound 3, area under the concentration-time curve: 98.5 ng.h/mL
Estimate against measurement, compound 3: 1.0-fold (0.02 log units) below; the range from low to high includes it.
By their numbers in this assay, from the lowest: compounds 1, 2 and 3 (each within the scatter of the next).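

On the aromatic carbon between two ring nitrogen atoms, (1-phenylethyl)amino brings a hydrogen-bond donor and a defined stereocentre in place of benzyl(methyl)amino, yet this assay shows no change at the digits printed from compound 2 to compound 3 (within the scatter) and, against the (2-ethoxyethyl)amino group, a 1.1-fold higher number from compound 1 to compound 3 (0.03 log units; within the scatter) as well. All three groups at this position therefore lie within the scatter of one another. Nothing available explains this flat result. Still open, from the compounds shown here alone, is whether the other stereoisomer of the 1-phenylethyl group would match these compounds. Also open, going by these compounds, is whether a carboxylic acid or a basic amine on this chain would shift exposure.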